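The source may report more compounds than this note shows. Statements on the series, on what has been measured and on what is new or still open speak of the compounds shown alone.

In an ADME assay on HEK-293T cells (Homo sapiens) for cytotoxicity, read by luminescence, with a stated time of 24 h (a lower number here means that less compound is tolerated, a higher number that more compound is tolerated), compound 1 `COc1ccc(Cn2c(C(=O)N3CCCC3)cc3sccc32)cc1` gives > 100000 nM, which is a limit of the assay and not a number. Going by the values given here, compound 2 `CCCNC(=O)C1CCN(C(=O)c2c(Br)c3sccc3n2Cc2ccc(OC)cc2)CC1` gives 31600 nM, the only true number available in this assay, so it has no measured neighbour to be ranked against.

Compound 3 `CCCNC(=O)C1CCN(C(=O)c2c(CNCc3ccccc3)c3sccc3n2Cc2ccc(OC)cc2)CC1` keeps the rest of compound 2 and changes in one place: (benzylamino)methyl in place of bromo on an aromatic carbon. Here (benzylamino)methyl stands in place of bromo on an aromatic carbon of a five-membered aromatic ring with 1 nitrogen, next to the ring atom that bears a large group.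

Among the compounds with values here, no two measured compounds differ in a single place, so no measured step gives the size of such a change. The expectation therefore starts from compound 2 at 31600 nM and remains a judgement. A modest move towards less compound being tolerated is expected, and the estimated change is a 2.3-fold lower number from compound 2 to compound 3 (0.35 log units; beyond the scatter). Compound 3 is expected to give about 14000 nM, with an estimated range of 4500 nM to 45000 nM.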

Compound 3, half-maximal cytotoxic concentration: 77600 nM
Beside the measured number, compound 3's estimate is 5.5-fold (0.74 log units) below it, and the stated range ends below it.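

The earlier compounds shown here gave no measured change at this position; the replacement of bromo by (benzylamino)methyl on this aromatic carbon now supplies one, with a 2.5-fold higher number from compound 2 to compound 3 (0.39 log units; beyond the scatter) in this assay. The entering group is much the larger of the two and brings a six-membered aromatic ring of carbon only, along with a hydrogen-bond donor and a hydrogen-bond acceptor, yet the number moves towards more compound being tolerated, not less. This single step shows that, in this pair, such a group at this place does not lower the number, although it gives no reason for the direction of the change.

The compounds shown leave open whether the step follows from the loss of bromo or from the arrival of the entering group, and how a plain methyl or an aminomethyl without the benzyl would compare at this place. How far any further replacement could raise the number is also bounded in this assay: the limit of > 100000 nM in this assay, at which 1 of the 3 values shown sits.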